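Isopropyl for Methyl on the Ring Nitrogen

This account rests on a few compounds, and the source may have more. Where it says the series, first, only, none or still open, it means among the compounds named here.

Compound 1 `CCOC(=O)c1ccc(OC(=O)c2ccc3c(c2)C(C)(C)CCN3C)cc1` is the starting point of this account. In a functional assay on CV-1 cells for activation of retinoic acid receptor beta (Homo sapiens) (on this read-out higher numbers stand for larger maximal responses and lower numbers for smaller maximal responses), compound 1 gives 64%. Among the measured compounds shown here, its one measured neighbour, compound 2 `CCOC(=O)c1ccc(OC(=O)c2cc3c(cc2C)N(C)CCC3(C)C)cc1`, gives 63% in this assay, and the step of a number 1 percentage points lower from compound 1 to compound 2 (within the scatter) stays within the scatter, so the two compounds cannot be told apart on this read-out; compound 1 merely holds the number that no other measured compound exceeds.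

Compound 3 `CCOC(=O)c1ccc(OC(=O)c2ccc3c(c2)C(C)(C)CCN3C(C)C)cc1` differs from compound 1 in one place: isopropyl in place of methyl on a nitrogen on an aromatic ring in a ring.

For the measured compounds named here, the only measured step, methyl in place of hydrogen on an aromatic carbon, touches a different part of the shared core and was a number 1 percentage points lower from compound 1 to compound 2 (within the scatter), within the scatter. Going by the values given here, no measured step changes the group on the ring nitrogen, so nothing here speaks for a shift in either direction. The account therefore expects the step of a number 4 percentage points lower from compound 1 to compound 3 (within the scatter) to be none beyond the scatter. Compound 3 is estimated to give 60% in this assay, with a range from 42% to 76%.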

Compound 3, largest response reached (reported as efficacy), in percent of the reference or control that the assay uses: 71%
Compound 3: the middle estimate sits 11 percentage points below what was measured; the range from low to high includes it.
By their numbers in this assay, from the lowest: compounds 2, 1 and 3 (each within the scatter of the next).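

Isopropyl in place of methyl on a nitrogen on an aromatic ring in a ring, with 3 heavy atoms entering where 1 leaves, gives a number 7 percentage points higher from compound 1 to compound 3 (within the scatter) in this assay on this read-out. Among the compounds shown here, this is the first measured step at the ring nitrogen, and it shows that this position can carry isopropyl without a shift that stands clear of the scatter, so compound 1 and compound 3 cannot be told apart here, just as compound 1 and compound 2 could not be told apart at the aromatic carbon. Nothing at hand bears on why methyl and isopropyl at this nitrogen read alike.

What the compounds shown leave open is whether a longer chain on the ring nitrogen, or a chain ending in an amine or a carboxylic acid, would move the maximal response beyond the scatter, since methyl and isopropyl alone mark out only a narrow part of what this position could hold. Also open, as far as these compounds go, is whether isopropyl on the ring nitrogen would read the same in a compound that also carries the methyl on the aromatic carbon found in compound 2.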